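Branching a Side Chain: An Estimate for Compound 4

The source may report more compounds than this note shows. Statements on the series, on what has been measured and on what is new or still open speak of the compounds shown alone.

Three compounds have been measured in a functional assay on L1210 cells (Mus musculus), with a stated time of 12 days; a higher number here means a more potent compound, by a factor of ten per unit of this negative logarithm, a lower number a less potent compound:
compound 1 `CC1=C(N2CC2)C(=O)C(C(C)COC(N)=O)=C(N2CC2)C1=O` gives 5.71;
compound 2 `CCC1=C(N2CC2)C(=O)C(CCOC(N)=O)=C(N2CC2)C1=O` gives 5.48;
compound 3 `CCC(COC(N)=O)C1=C(N2CC2)C(=O)C(C)=C(N2CC2)C1=O` gives 5.66.

All three numbers lie within the usual scatter of one another, so none of the three can be set apart from the others. Compound 3 differs from compound 1 by methyl in place of hydrogen on a saturated chain carbon, two bonds along the chain from a double-bonded ring carbon, and that change gave a number 0.05 log units lower from compound 1 to compound 3 (within the scatter). Compound 2 shares its atoms with compound 1 but joins them differently; the difference between the two cores is not broken down here.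

Compound 4 `CCCC1=C(N2CC2)C(=O)C(CCOC(N)=O)=C(N2CC2)C1=O` has not yet been measured. Among the compounds with values here, it differs from compound 2 by methyl in place of hydrogen on a saturated chain carbon, two bonds along the chain from a double-bonded ring carbon, which is the same change as the one made from compound 1 to compound 3, at the same kind of place. Because that earlier change gave a number 0.05 log units lower from compound 1 to compound 3 (within the scatter), a similarly small step is expected here, so the estimate for the step is a number 0.03 log units lower from compound 2 to compound 4 (within the scatter). On that basis compound 4 is estimated to give 5.45 in this assay, with a range from 5.1 to 5.8.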

Compound 4, logarithm of the reciprocal of the active concentration, log(1/C): 5.23
Beside the measured number, compound 4's estimate is 0.22 log units above it; the range from low to high includes it.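

In this assay the methyl in place of hydrogen gave a number 0.25 log units lower from compound 2 to compound 4 (within the scatter) and so, like the earlier step, it cannot be told apart from the ordinary spread of repeated measurements. Set side by side, the two steps do not differ measurably, which means the change carried over from one core to the other with no detectable difference: the same change on two cores in this assay, a number 0.05 log units lower (within the scatter) from compound 1 to compound 3 and a number 0.25 log units lower (within the scatter) from compound 2 to compound 4, 0.20 log units apart, within the scatter of two such steps

Within the data shown here, this agreement rests on only two pairs of compounds, and both steps lie within the scatter, so it shows neither that the methyl truly has no effect nor that the change would behave the same way on any further core.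

The compounds shown leave open what a longer chain, such as butyl or hexyl, would do at this place, and whether the number would then move beyond the scatter. They also leave open how a hydroxyl group or an amine on that chain would compare with the plain ethyl and propyl chains.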